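Replacing an Amide Group With Chloro

This account rests on a few compounds, and the source may have more. Where it says the series, first, only, none or still open, it means among the compounds named here.

- compound 1 `C#Cc1cccc(-c2nccc3nc(N)nn23)c1`: 12600 nM; 12600 nM (2 entries)
- compound 2 `CN(C)C(=O)c1cccc(-c2nccc3nc(N)nn23)c1`: 3500 nM

In a functional assay (Homo sapiens) (a higher number here means a weaker inhibitor, a lower number a stronger inhibitor), compound 2 gives 3500 nM as its reading, while compound 1 gives the higher 12600 nM; 12600 nM (2 entries) and so inhibits more weakly. Compound 3 `Nc1nc2ccnc(-c3cccc(Cl)c3)n2n1` has chloro in place of dimethylcarbamoyl on an aromatic carbon. For the measured compounds named here, no measured step shows this change directly. Compound 1 also lacks the dimethylcarbamoyl and gives 12600 nM; 12600 nM (2 entries) in this assay, so a modest weakening is expected. The estimate is a 1.7-fold higher number from compound 2 to compound 3 (0.23 log units; within the scatter) as the expected step. For compound 3 the estimated value is 6000 nM within a range from 1500 nM to 20000 nM in this measurement.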

Compound 3, half-maximal inhibitory concentration: 4300 nM
Compound 3: middle estimate off by 1.4-fold (0.14 log units), on the high side; low and high end bracket the measured number.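

In this assay, swapping the dimethylcarbamoyl for chloro gives a 1.2-fold higher number from compound 2 to compound 3 (0.09 log units; within the scatter), so the two compounds cannot be told apart. On this aromatic carbon, then, a group of 5 heavy atoms with 1 hydrogen-bond acceptor gives way to a single chlorine atom with no measurable loss, and the amide is not needed to keep this reading. As far as these compounds go, what stays open is how an amine or a carboxylic acid on the same carbon would read. Nothing measured here gives a reason for the match between compound 2 and compound 3.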